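Shifting the Hydroxy Group from Compound 3 to Compound 4

The compounds below may be only part of what the source reports. "The series", "measured", "known", "first", "only" and "open" are said of these compounds alone.

Compound 1 `Cc1ccc(S(=O)(=O)Nc2ccc3oc(-c4ccccc4)nc3c2)cc1` gives > 63000 nM in an assay on isolated protein for inhibition of malate dehydrogenase, mitochondrial (Sus scrofa), with stated times of 45 min and 30 min (on this read-out higher numbers stand for weaker inhibition and lower numbers for stronger inhibition), a limit.
Compound 2 `O=S(=O)(Nc1ccc2oc(-c3ccccc3)nc2c1)c1ccc(Cl)cc1` gives > 63000 nM in this assay, a limit.
Compound 3 `O=S(=O)(Nc1ccc2oc(-c3ccccc3)nc2c1)c1ccc(O)cc1` gives > 63000 nM in this assay, a limit.

Compound 3 stands at the limit where all three measured values sit (the limit of > 63000 nM in this assay, at which 3 of the 3 values shown sit), so it cannot be ranked against compound 1 or compound 2. Compound 4 `O=S(=O)(Nc1ccc2oc(-c3ccccc3)nc2c1)c1ccccc1O` differs from compound 3 by 2-hydroxyphenyl in place of 4-hydroxyphenyl on a sulfonyl sulfur. The measured steps bear only loosely on this change: a step that the two limits leave unreadable from compound 1 to compound 2, a step that the two limits leave unreadable from compound 1 to compound 3 and a step that the two limits leave unreadable from compound 2 to compound 3 each alter the group on the sulfonyl sulfur, and none of them can be read in size because the limit of > 63000 nM in this assay, at which 3 of the 3 values shown sit, holds both ends of each. With every variation of that group so far leaving the limit untouched, compound 4 is expected to stay at the limit as well, an expected step that the limit leaves unreadable from compound 3 to compound 4. The estimate for compound 4 in this assay is 100000 nM, expected within 30000 nM to 500000 nM.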

Compound 4, half-maximal inhibitory concentration: > 63000 nM
Compound 4 ended at the assay's limit; the forecaster's own chance of this, stated with the estimate: 85%; the middle value lies beyond the limit too.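

Among the compounds shown here, no step from compound 1, compound 2 or compound 3 to compound 4 can be read in this assay, since all four compounds sit at a limit: the limit of > 63000 nM in this assay, at which 4 of the 4 values shown sit. The compounds shown leave open whether any group on the sulfonyl sulfur gives a readable value in this assay.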